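A few compounds are considered here, and "the series" means these few. Any claim that something is new, unique, unknown or untested is made for them only; others in the source may bear on it.

Measured compounds in an ADME assay for pharmacokinetics, read by LC-MS, in phosphate buffer, with a stated time of 72 h, at pH 7.4, tested at 250 uM; on this read-out higher numbers stand for a longer-lived compound and lower numbers for a shorter-lived compound:
- compound 1 `C=CC(=O)Oc1cc(C(F)(F)F)cc(C(F)(F)F)c1` gives < 0.017 h, a limit of the assay
- compound 2 `O=C1C=CC(=O)N1c1cc(C(F)(F)F)cc(C(F)(F)F)c1` gives < 0.017 h, a limit of the assay
- compound 3 `C=Cc1cc(C(F)(F)F)cc(C(F)(F)F)c1` gives > 50 h, a limit of the assay

Compound 3 stands at the upper edge of the numbers shown, where its value is a limit and not a number (the limit of > 50 h in this assay, at which 1 of the 3 values shown sits). The two other values sit at the lower limit (the limit of < 0.017 h in this assay, at which 2 of the 3 values shown sit). The steps into compound 3 are both large: an at least 2900-fold higher number from compound 1 to compound 3 (3.46 log units; beyond the scatter) and an at least 2900-fold higher number from compound 2 to compound 3 (3.46 log units; beyond the scatter). Their sizes are lower bounds, since limits lie at both ends.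

Compound 4 `C#Cc1cc(C(F)(F)F)cc(C(F)(F)F)c1` differs from compound 3 by ethynyl in place of vinyl on an aromatic carbon. For the measured compounds named here, no measured step exchanges one hydrocarbon group for another; the two measured steps only remove an acryloyl ester or a maleimide and each time the read-out jumps to the upper limit. Compound 4 keeps a hydrocarbon substituent, so the expected step that the limit leaves unreadable from compound 3 to compound 4 in this assay is none beyond the scatter. The half-life of compound 4 is therefore estimated at 60 h, between 15 h and 250 h, most likely reported again as a limit.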

Compound 4, half-life: > 50 h
Compound 4 ended at the assay's limit; the forecaster's own chance of this, stated with the estimate: 80%; the middle value is on the limit's open side.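

In this assay compound 4 gives > 50 h, which is a limit of the assay. A second hydrocarbon group on this aromatic carbon, meta to two trifluoromethyl groups, thus reaches the upper limit, now with ethynyl and its triple bond in place of vinyl and its double bond, and the steps from the other two compounds stay large: an at least 2900-fold higher number from compound 1 to compound 4 (3.46 log units; beyond the scatter) and an at least 2900-fold higher number from compound 2 to compound 4 (3.46 log units; beyond the scatter). The step from compound 3 to compound 4 cannot be read, so no order can be given between vinyl and ethynyl: the limit of > 50 h in this assay, at which 2 of the 4 values shown sit.

On these data alone, how far the half-lives of compound 3 and compound 4 reach past that limit remains open. So does the behaviour of an ethyl group, a nitrile or an amine at this position, or of an acrylamide in place of the acryloyl ester.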